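The source may hold more compounds than are shown below. What is called first, only, known or untested is meant among the compounds shown, and "the series" means these compounds.

Compound 1 `COc1ccc(F)cc1N1C(=O)CSC1c1cccc(C(=O)NCCCCn2cccn2)c1`: 1310 mL.min-1.g-1
Compound 2 `O=C(NCCCCn1cccn1)c1cccc(C2SCC(=O)N2c2ccccn2)c1`: 304 mL.min-1.g-1
Compound 3 `O=C(NCCCCc1ccccc1)c1cccc(C2SCC(=O)N2c2cccc(-c3c[nH]nn3)c2)c1`: 951 mL.min-1.g-1

All three values come from an ADME assay on microsomes from liver (Mus musculus) for metabolic stability, read by LC-MS, using NADPH, with a stated time of 10 min, tested at 0.1 uM; a higher number here means faster removal of the compound, a lower number slower removal. Compound 3, at 951 mL.min-1.g-1, lies within the usual scatter of compound 1 and clearly above compound 2.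

Compound 4 `O=C(NCCCCc1ccccc1)c1cccc(C2SCC(=O)N2c2cccc(F)c2)c1` differs from compound 3 in one place: fluoro in place of 1H-1,2,3-triazol-4-yl on an aromatic carbon. Among the compounds with values here, no measured pair makes this exact swap, so the evidence is indirect. The nearest guide is a 4.3-fold lower number from compound 1 to compound 2 (0.63 log units; beyond the scatter), where pyridin-2-yl replaces 5-fluoro-2-methoxyphenyl on an amide-type nitrogen in a ring. That step shows that the aromatic group on this nitrogen can matter in this assay, but it involves another group and another side chain. Compound 1, which carries a fluorinated phenyl group there, gives 1310 mL.min-1.g-1, so a large drop seems unlikely.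

The expected step is a 1.2-fold higher number from compound 3 to compound 4 (0.06 log units; within the scatter), and it is not expected to exceed the scatter. For compound 4 the estimated value is 1100 mL.min-1.g-1, with an expected range of 500 mL.min-1.g-1 to 2400 mL.min-1.g-1.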

Compound 4, intrinsic clearance in microsomes: 2740 mL.min-1.g-1
Estimate against measurement, compound 4: 2.5-fold (0.40 log units) below; the whole stated range lies below it.
By their numbers in this assay, from the lowest: compound 2; then compounds 3 and 1 (each within the scatter of the next); then compound 4.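

In this assay, the step of a 2.9-fold higher number from compound 3 to compound 4 (0.46 log units; beyond the scatter) shows that the group at this place, meta to a large group on the aromatic ring, can alone move the number beyond the scatter. Compounds 1 and 2 differ in the whole aromatic group on the ring nitrogen, whereas this pair differs in a single substituent on that group, and removal is faster with fluoro than with 1H-1,2,3-triazol-4-yl. Nothing measured here accounts for the rise.

This one swap cannot separate the loss of the triazolyl group from the arrival of fluoro. A plain hydrogen, an amine or a carboxylic acid at the same place would help to show which of the two the number follows, and whether other groups give a lower number.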